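A few compounds are considered here, and "the series" means these few. Any claim that something is new, unique, unknown or untested is made for them only; others in the source may bear on it.

Compound 3 `CCOC(=O)c1cc2cc(/C=C/C(=O)c3ccccc3)cc(C(C)CC)c2oc1=O` has the lowest of the two numbers recorded in a functional assay on A549 cells (Homo sapiens) for cytotoxicity, read by sulforhodamine B assay, with a stated time of 48 h (a lower number here means a stronger inhibitor, a higher number a weaker inhibitor), at 12900 nM; its nearest neighbour is compound 2 `CCOC(=O)c1cc2cc(/C=C/C(=O)c3ccc(C)cc3)cc(C(C)CC)c2oc1=O`, which gives 32800 nM. Compound 1 `CCC(C)c1cc(/C=C/C(=O)c2ccc(Cl)cc2)cc2cc(C(C)=O)c(=O)oc12` is reported in this assay only as "not active" (no number reported), without a number. Among the measured compounds shown here, the single step that bears on the next compound is a 2.5-fold lower number from compound 2 to compound 3 (0.41 log units; beyond the scatter), where a substituent was removed from the same aromatic carbon. Compound 4 `CCOC(=O)c1cc2cc(/C=C/C(=O)c3ccc(Cl)cc3)cc(C(C)CC)c2oc1=O` differs from compound 3 by chloro in place of hydrogen on an aromatic carbon. Since removing a methyl there lowered the number modestly, adding a chloro is expected to move it modestly the other way, a step of about a 1.7-fold higher number from compound 3 to compound 4 (0.23 log units; within the scatter). Compound 4 is therefore estimated at 22000 nM, within a range of 7000 nM to 65000 nM.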

Compound 4, half-maximal inhibitory concentration: 12900 nM
Estimate against measurement, compound 4: 1.7-fold (0.23 log units) above; low and high end bracket the measured number.
By their numbers in this assay, from the lowest: compounds 3 and 4 (each within the scatter of the next); then compound 2.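

At this aromatic carbon, this assay gives no change at the digits printed from compound 3 to compound 4 (within the scatter), so adding a group here does not by itself raise the number as the earlier step suggested. Set against methyl, chloro gives a 2.5-fold lower number from compound 2 to compound 4 (0.41 log units; beyond the scatter), which leaves methyl as the only one of the three groups shown that stands apart. Nothing given here explains this result.

As far as these compounds go, it remains open whether a methoxy group, an amine or a carboxylic acid at this carbon would match hydrogen and chloro or follow methyl.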